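A Bromine for a Methyl on the Amide Nitrogen

The compounds below may be only part of what the source reports. "The series", "measured", "known", "first", "only" and "open" are said of these compounds alone.

Compound 2 `Cc1cccc(NC(=O)c2ccc3cccc(O)c3n2)c1` carries a 3-methylphenyl on an amide-type nitrogen. In a physicochemical assay for lipophilicity, read by HPLC (a lower number here means a more polar compound, a higher number a more lipophilic compound), compound 2 gives 2.5. Its nearest neighbour is compound 1 `Cc1ccccc1NC(=O)c1ccc2cccc(O)c2n1`, which in this assay gives 2.5; the move no change at the digits printed from compound 1 to compound 2 (within the scatter) left the read-out unchanged within the scatter, so compound 2 stands level with compound 1.

Compound 3 `O=C(Nc1ccc(Br)cc1)c1ccc2cccc(O)c2n1` differs from compound 2 in one place: 4-bromophenyl in place of 3-methylphenyl on an amide-type nitrogen. Among the measured compounds shown here, no measured step swaps a bromine for a methyl, so the one step known, no change at the digits printed from compound 1 to compound 2 (within the scatter), which only moved the methyl, is at best a weak guide. The expectation is a small rise, and the step of a number 0.30 log units higher from compound 2 to compound 3 (within the scatter) is the estimated shift. Compound 3 is therefore expected to give 2.8 in this assay, with a likely range from 2.4 to 3.2.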

Compound 3, partition coefficient: 2.5
Compound 3: the middle estimate sits 0.30 log units above what was measured, within the range that was stated.
By their numbers in this assay, from the lowest: compounds 1, 2 and 3 (each within the scatter of the next).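

In this assay the swap of 3-methylphenyl for 4-bromophenyl gives no change at the digits printed from compound 2 to compound 3 (within the scatter) and the swap of 2-methylphenyl for 4-bromophenyl gives no change at the digits printed from compound 1 to compound 3 (within the scatter) on the same amide-type nitrogen. The earlier pair differed only in where a methyl sat on the phenyl, whereas here a bromine takes the place of that methyl and all three compounds still stand level. Nothing at hand explains why these groups read alike.

From the compounds shown here alone, it remains open whether that level reading would hold for a phenyl carrying an amine or a carboxylic acid, or for a longer alkyl chain in place of the phenyl. Going by these compounds, all three compounds carry a substituted phenyl here, so the kind of group that would shift this number beyond the scatter is still unknown.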